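Adding a hydroxy group to the ring that carries the benzyl

This account rests on a few compounds, and the source may have more. Where it says the series, first, only, none or still open, it means among the compounds named here.

Of the compounds shown here, two with a shared core have been measured in an assay on CHO cells with Substance-P receptor (Homo sapiens) as the target; a higher number here means a weaker inhibitor, a lower number a stronger inhibitor. Compound 1 `CC(C)N1CCN(C(=O)CCc2c(-c3ccc(Cl)cc3)n(C)c3ccc(Cl)cc23)CC1` gives 13 nM in this assay. Compound 2 `Cn1c(-c2ccc(Cl)cc2)c(CCC(=O)N2CCC(Cc3ccccc3)CC2)c2cc(Cl)ccc21` gives 2.2 nM in this assay, the lower of the two numbers and therefore the stronger inhibitor of the pair, with a gap to compound 1 that is wider than the usual scatter of repeated measurements.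

The step under consideration leads from compound 2 to compound 3 `Cn1c(-c2ccc(Cl)cc2)c(CCC(=O)N2CCC(O)(Cc3ccccc3)CC2)c2cc(Cl)ccc21`. The change is small in size: hydroxy in place of hydrogen on a saturated ring carbon. Among the measured compounds shown here, no measured pair in the set shows what such an exchange does here, so the expectation rests on the structural change alone. Because compound 2 already gives 2.2 nM, compound 3 is expected to stay close to it, with any shift in this assay likely no larger than the scatter, and if there is a direction, a slightly weaker inhibitor. The estimate for compound 3 in this assay is 3.5 nM, between 1.2 nM and 11 nM, which amounts to an expected step of a 1.6-fold higher number from compound 2 to compound 3 (0.20 log units; within the scatter).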

Compound 3, half-maximal inhibitory concentration: 0.21 nM
For compound 3 the middle estimate is 17-fold (1.22 log units) above the measured one, and the stated range ends above it.
By their numbers in this assay, from the lowest: compound 3; then compound 2; then compound 1.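

In this assay, hydroxy in place of hydrogen on this saturated ring carbon, three ring bonds from the ring nitrogen, gives a 10-fold lower number from compound 2 to compound 3 (1.02 log units; beyond the scatter), a large change that lies beyond the scatter. The earlier compounds shown here could not show that this position responds so strongly: one added oxygen atom, bringing a hydrogen-bond donor and acceptor, yields a clearly stronger inhibitor even though compound 2 already stood at 2.2 nM. The compounds shown contain no separate measurement that accounts for this gain, so the size of the step is recorded here without an explanation.

On these data alone, it remains open whether the gain is particular to hydroxy, since a methoxy group, an amine or a fluorine on the same ring carbon would be needed to tell that apart. Also unresolved is whether the hydroxy would give a step of similar size if the benzyl were replaced by a longer chain, such as phenethyl, or if the phenyl ring of the benzyl carried a chlorine.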